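The source may hold more compounds than are shown below. What is called first, only, known or untested is meant among the compounds shown, and "the series" means these compounds.

Measured so far in a functional assay on MCF7 cells (Homo sapiens) for cytotoxicity, read by MTT assay, with a stated time of 72 h; a lower number here means a stronger inhibitor of growth, a higher number a weaker inhibitor of growth:
compound 1 `C=CCOC(=O)Nc1ccc([Se]C#N)cc1` gives 15000 nM
compound 2 `CCOC(=O)Nc1ccc([Se][Se]c2ccc(NC(=O)OCC)cc2)cc1` gives 9900 nM
compound 3 `Cc1ccc(OC(=O)Nc2ccc([Se][Se]c3ccc(NC(=O)Oc4ccc(C)cc4)cc3)cc2)cc1` gives 6900 nM

Among these three, compound 1 has the highest number in this assay. The gap to compound 2 falls within the usual scatter, so nothing can be said of an order between them, while compound 3 sits beyond the scatter with the lower number. Compound 4 `CCCCCCOC(=O)Nc1ccc([Se]C#N)cc1` has not yet been measured. It differs from compound 1 in one place: pentyl in place of vinyl on a saturated chain carbon bound to an oxygen next to a carbonyl group. Among the measured compounds shown here, no measured pair shows this change, so the estimate rests on compound 1 alone, at 15000 nM. The expected step of a 1.5-fold lower number from compound 1 to compound 4 (0.18 log units; within the scatter) is small, toward a lower number, and not beyond the scatter. Compound 4 is therefore estimated at 10000 nM, with a range from 4000 nM to 30000 nM.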

Compound 4, concentration for 50% growth inhibition: 6600 nM
Compound 4: the middle estimate sits 1.5-fold (0.18 log units) above what was measured; the measured number falls inside the stated range.
By their numbers in this assay, from the lowest: compounds 4, 3, 2 and 1 (each within the scatter of the next, the first and the last beyond it).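

In this assay, hexyl-type lengthening at this place, pentyl in place of vinyl on a saturated chain carbon bound to an oxygen next to a carbonyl group, gives a 2.3-fold lower number from compound 1 to compound 4 (0.36 log units; beyond the scatter). Among the compounds shown here, this is the first single-place comparison, and it shows that the number responds to this change. Nothing measured here explains the step.

This one pair changes chain length and removes the double bond together, so it cannot separate the two. As far as these compounds go, whether a longer chain, a branched chain or a terminal amine here would lower the number further remains open.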